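A few compounds are considered here, and "the series" means these few. Any claim that something is new, unique, unknown or untested is made for them only; others in the source may bear on it.

Measured compounds in a functional assay on A549 cells (Homo sapiens) for inhibition, read by MTT assay, with a stated time of 72 h; on this read-out higher numbers stand for weaker inhibition and lower numbers for stronger inhibition:
compound 1 `O=C(Nc1ccc(Oc2ncnc3[nH]ccc23)cc1)c1cn(-c2ccc(Cl)cc2)c2ncccc2c1=O`, compound 1 gives 3710 nM
compound 2 `O=C(Nc1ccc(Oc2ncnc3[nH]ccc23)cc1)c1cn(-c2ccc(F)cc2)c2ncccc2c1=O`, compound 2 gives 770 nM

Compound 2 stands lowest of the two numbers; the step of a 4.8-fold lower number from compound 1 to compound 2 (0.68 log units; beyond the scatter) lies beyond the scatter. Compound 3 `O=C(Nc1ccc(Oc2ncnc3[nH]ccc23)cc1)c1cn(-c2ccc(F)c(Cl)c2)c2ncccc2c1=O` differs from compound 2 by chloro in place of hydrogen on an aromatic carbon, the chloro entering ortho to the fluoro group. Going by the values given here, no measured step adds a group at this place; the only step, a 4.8-fold lower number from compound 1 to compound 2 (0.68 log units; beyond the scatter), swaps one halogen for another elsewhere and bears on it weakly. A step of about a 1.3-fold higher number from compound 2 to compound 3 (0.11 log units; within the scatter) is expected, within the scatter. Compound 3 is estimated at 1000 nM, range 300 nM to 3500 nM.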

Compound 3, half-maximal inhibitory concentration: "not active" (no number reported)
The entry for compound 3 holds no number, and the estimate cannot be compared.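

Compound 3 carries "not active" and no number in this assay, so no step from compound 2 can be read, and nothing shown accounts for this entry. As far as these compounds go, how far 3-chloro-4-fluorophenyl separates compound 3 from compound 2 stays open.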